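This account rests on a few compounds, and the source may have more. Where it says the series, first, only, none or still open, it means among the compounds named here.

Measured in a functional assay on SK-BR-3 cells (Homo sapiens) for antiproliferative activity; on this read-out higher numbers stand for weaker inhibition and lower numbers for stronger inhibition:
- compound 1 `COc1ccc(C(=O)Nc2cc3ccc(OC4CCN(C)CC4)c(C)c3oc2=O)cc1CC=C(C)C`: 1410 nM
- compound 2 `Cc1c(OC2CCN(C)CC2)ccc2cc(NC(=O)c3ccc(O)c(CCC(C)C)c3)c(=O)oc12`: 600 nM
- compound 3 `Cc1c(OC2CCN(C)CC2)ccc2cc(NC(=O)c3ccc(O)c(Cl)c3)c(=O)oc12`: 2300 nM

The number for compound 1 lies within the scatter of the number for compound 3, while compound 2 stands lower, beyond the scatter.

Compound 4 `CC(C)=CCc1cc(C(=O)Nc2cc3ccc(OC4CCN(C)CC4)c(C)c3oc2=O)ccc1OC1CCN(C)CC1` keeps the core of compound 1 and changes one group: 1-methylpiperidin-4-yl in place of methyl on an oxygen on an aromatic ring. Put simply, 1-methylpiperidin-4-yl stands in place of methyl on an oxygen on an aromatic ring, so methoxy becomes (1-methylpiperidin-4-yl)oxy.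

For the measured compounds named here, no measured step touches this group. Going by the values given here, the only step at a single place, a 3.8-fold higher number from compound 2 to compound 3 (0.58 log units; beyond the scatter), puts chloro in place of isopentyl on an aromatic carbon. It is a different change, and it was modest. It hints only at how far one swap can move the number in this small set, and it gives no direction for compound 4. No clear shift beyond the scatter is therefore expected, though a modest move either way remains possible. The expected step in this assay is a 1.1-fold higher number from compound 1 to compound 4 (0.03 log units; within the scatter). Compound 4 is estimated at 1500 nM, with an expected range of 450 nM to 5000 nM.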

Compound 4, half-maximal inhibitory concentration: 210 nM
Compound 4: the middle estimate sits 7.1-fold (0.85 log units) above what was measured; the whole stated range lies above it.
By their numbers in this assay, from the lowest: compound 4; then compound 2; then compounds 1 and 3 (each within the scatter of the next).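

In this assay, the group on this oxygen proves to matter: putting (1-methylpiperidin-4-yl)oxy in place of methoxy gives a 6.7-fold lower number from compound 1 to compound 4 (0.83 log units; beyond the scatter) and so stronger inhibition. For the compounds shown here, none of the earlier steps touched this place, and this one shows that a far larger group, carrying a six-membered non-aromatic ring with one nitrogen, is not only tolerated here on this read-out but gives a lower number than methyl does. No measurement at hand explains the gain.

The compounds shown leave open which part of the new group goes with the lower number, the ring or its nitrogen. A cyclohexyl group, which has the ring without the nitrogen, or an open dimethylaminoethyl chain, which has an amine without the ring, on the same oxygen would begin to separate the two.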